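A few compounds are considered here, and "the series" means these few. Any claim that something is new, unique, unknown or untested is made for them only; others in the source may bear on it.

Notes on the sulfonyl series in an ADME assay on HCT-116 cells (Homo sapiens) for cytotoxicity, read by CellTiter-Glo, with a stated time of 72 h; a higher number here means a weaker inhibitor, a lower number a stronger inhibitor. Compound 3 (`CC1CCN(C2CCN(S(=O)(=O)c3ccc(C#N)cc3)CC2)CC1`) gives > 5000 nM, a limit and not a number. Compound 1 (`Cc1noc(C)c1S(=O)(=O)N1CCC(N2CCC(C)CC2)CC1`) gives > 10000 nM, also a limit. Compound 2 (`CC1CCN(C2CCN(S(=O)(=O)c3cccnc3Cl)CC2)CC1`) gives > 10000 nM, again a limit. Going by the values given here, no compound in the set therefore has a readable value, and compound 3 has no measured position relative to the other two.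

Compound 4 (`CC1CCN(C2CCN(S(=O)(=O)c3cccnc3)CC2)CC1`) keeps the shared core and takes pyridin-3-yl in place of 4-cyanophenyl on the sulfonyl sulfur: pyridin-3-yl in place of 4-cyanophenyl on a sulfonyl sulfur.

The measured steps that bear on this change are those on the same sulfur. The closest is a step that the two limits leave unreadable from compound 2 to compound 3, since the group in compound 2 is the 2-chloropyridin-3-yl. The others are a step that the two limits leave unreadable from compound 1 to compound 3 and a step that the two limits leave unreadable from compound 1 to compound 2. None of the three gives a size, so none supplies a direction. All three groups tested so far ended at a limit, and the same outcome is expected for pyridin-3-yl.

In this assay, the expected result is a step that the limit leaves unreadable from compound 3 to compound 4, with no change expected beyond the scatter. For compound 4 the estimated value is 10000 nM, with an expected range from 5000 nM to 20000 nM.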

Compound 4, half-maximal inhibitory concentration: > 10000 nM
Compound 4: only a limit was reported; the forecaster's own chance of this, stated with the estimate: 85%; the middle value sits exactly at the limit.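

In this assay compound 4 gives > 10000 nM, a limit and not a number. Its steps to compound 1, compound 2 and compound 3 cannot be read, as all four values are limits. The compounds shown leave open whether any of these groups on the sulfonyl sulfur differ at all in this assay, and by how much.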